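The compounds below may be only part of what the source reports. "The series", "measured", "known", "first", "only" and "open" are said of these compounds alone.

Of the compounds shown here, three have been measured in an assay on isolated protein for inhibition of histone deacetylase 8 (Homo sapiens), with a stated time of 1 h; a lower number here means a stronger inhibitor, a higher number a weaker inhibitor: compound 1 `Cc1ccc(NC(=O)COc2ccc3cc(/C=C4/SC(=O)NC4=O)ccc3c2)cc1` at 9000 nM, compound 2 `O=C(COc1ccc2cc(/C=C3/SC(=O)NC3=O)ccc2c1)Nc1cccc(F)n1` at 7200 nM, and compound 3 `Cc1cc(Br)ccc1NC(=O)COc1ccc2cc(/C=C3/SC(=O)NC3=O)ccc2c1` at 7400 nM.

On the numbers as they stand, compound 3 holds the second highest of the three, but neither gap is telling: a 1.0-fold higher number from compound 2 to compound 3 (0.01 log units; within the scatter) and a 1.2-fold lower number from compound 1 to compound 3 (0.09 log units; within the scatter). Compound 4 `O=C(COc1ccc2cc(/C=C3/SC(=O)NC3=O)ccc2c1)Nc1ccc(F)cc1` carries 4-fluorophenyl in place of 4-bromo-2-methylphenyl on an amide-type nitrogen. Every step known so far exchanges the aryl group on that same amide-type nitrogen, and none of them moves the number beyond the scatter: a 1.3-fold lower number from compound 1 to compound 2 (0.10 log units; within the scatter), a 1.2-fold lower number from compound 1 to compound 3 (0.09 log units; within the scatter) and a 1.0-fold higher number from compound 2 to compound 3 (0.01 log units; within the scatter). A further aryl group in the same place is therefore expected to behave alike, so that a 1.0-fold higher number from compound 3 to compound 4 (0.01 log units; within the scatter) is estimated to be no step beyond the scatter. Compound 4 is accordingly estimated at 7500 nM, with a range from 3500 nM to 16000 nM.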

Compound 4, half-maximal inhibitory concentration: 6600 nM
Estimate against measurement, compound 4: 1.1-fold (0.06 log units) above; low and high end bracket the measured number.
By their numbers in this assay, from the lowest: compounds 4, 2, 3 and 1 (each within the scatter of the next).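

In this assay compound 4 shows that taking the aryl group on the amide-type nitrogen to 4-fluorophenyl leaves the number within the scatter, whether it replaces 4-bromo-2-methylphenyl (a 1.1-fold lower number from compound 3 to compound 4 (0.05 log units; within the scatter)) or 6-fluoropyridin-2-yl (a 1.1-fold lower number from compound 2 to compound 4 (0.04 log units; within the scatter)). A single exchange on the ring itself, fluoro in place of methyl on an aromatic carbon, also stays within the scatter (a 1.4-fold lower number from compound 1 to compound 4 (0.13 log units; within the scatter)). Nothing at hand explains why these exchanges change so little.

Still open, from the compounds shown here alone, is whether a non-aryl group on that nitrogen, such as cyclohexyl or a longer alkyl chain, would move the number beyond the scatter. The same holds for an amine or a carboxylic acid on the aryl ring.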